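Replacing an Aryl Piperazine Cap with a Carbamate

The source may hold more compounds than are shown below. What is called first, only, known or untested is meant among the compounds shown, and "the series" means these compounds.

Measured compounds:
compound 1, `CCCCCCCCn1cc(/C=C/C(=O)c2ccc(N)cc2)nn1`, giving 26900 nM in a functional assay on A549 cells (Homo sapiens) for inhibition, read by MTT assay; on this read-out lower numbers stand for stronger inhibition and higher numbers for weaker inhibition
compound 2, `COc1ccccc1N1CCN(CC(=O)Nc2ccc(C(=O)/C=C/c3cn(Cc4ccc(Br)cc4)nn3)cc2)CC1`, giving 34000 nM in this assay

Both compounds share a chalcone-like core carrying a triazole, and both act only weakly in this assay. Compound 2 and compound 1 lie within the usual scatter of each other, so neither number can be separated from the other; compound 2 simply stands beside compound 1 at the weak end of what has been measured.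

Compound 3, `CC(C)(C)OC(=O)N1CCN(CC(=O)Nc2ccc(C(=O)/C=C/c3cn(Cc4ccc(Br)cc4)nn3)cc2)CC1`, has not yet been measured. It differs from compound 2 in one place: tert-butoxycarbonyl in place of 2-methoxyphenyl on an amine nitrogen in a ring. Among the compounds with values here, no step between two measured compounds shows what such an exchange does, so nothing in the data points in either direction. Compound 3 is therefore expected to stay close to compound 2, with the step of a 1.1-fold lower number from compound 2 to compound 3 (0.03 log units; within the scatter) expected to fall within the scatter. The estimate for compound 3 in this assay is 32000 nM, with a range from 10000 nM to 100000 nM.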

Compound 3, half-maximal inhibitory concentration: 38400 nM
The estimate for compound 3 lay 1.2-fold (0.08 log units) below the measured number; measured number inside the range.
By their numbers in this assay, from the lowest: compounds 1, 2 and 3 (each within the scatter of the next).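

In this assay, within the data shown here, the exchange on the amine nitrogen in a ring gives the first step that can be read at this position (a 1.1-fold higher number from compound 2 to compound 3 (0.05 log units; within the scatter)), and it lies within the scatter. A tert-butoxycarbonyl group, which has no ring, thus takes the place of 2-methoxyphenyl, with its six-membered aromatic ring, and the two compounds cannot be told apart, so at this position and in this pair the aromatic ring is not required for the number seen with compound 2. Nothing available explains why the two groups read alike.

Going by these compounds, it remains open whether a methyl group, an acetyl group or a plain hydrogen on this nitrogen would move the number beyond the scatter. This single step also cannot show whether a carboxylic acid or an amine at the end of this cap would change the reading.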